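The compounds below may be only part of what the source reports. "The series", "measured", "known", "first", "only" and "open" are said of these compounds alone.

Compound 1 `O=S(=O)(NCC1COC1)c1cccc(-c2ccc3nccc(-c4ccncc4)c3n2)c1`: 20000 nM
Compound 2 `NS(=O)(=O)c1cccc(-c2ccc3nccc(N4CCN(Cc5ccccc5)CC4)c3n2)c1`: < 5000 nM

In a physicochemical assay for solubility, read by HPLC, using the shake flask method, measured as kinetic solubility, with a stated time of 20 h, at pH 6.5, tested at 200 uM (a higher number here means a more soluble compound, a lower number a less soluble compound), compound 1 gives the only real number shown, 20000 nM. Compound 2 reaches only a limit of this assay, < 5000 nM, which is the limit of < 5000 nM in this assay, at which 1 of the 2 values shown sits. Compound 3 `O=S(=O)(CCO)c1cccc(-c2ccc3nccc(-c4ccncc4)c3n2)c1` differs from compound 1 by 2-hydroxyethyl in place of ((oxetan-3-yl)methyl)amino on a sulfonyl sulfur. For the measured compounds named here, no step between measured compounds is available to guide this change, so compound 3 is expected to stay within the usual scatter of compound 1. The expected step is no change at the digits printed from compound 1 to compound 3 (within the scatter), no more than the scatter. The estimate for compound 3 is 20000 nM, with a range from 8000 nM to 50000 nM.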

Compound 3, solubility: 55000 nM
Beside the measured number, compound 3's estimate is 2.8-fold (0.44 log units) below it; measured number above the stated range.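

At the sulfonyl sulfur, 2-hydroxyethyl in place of ((oxetan-3-yl)methyl)amino gives a 2.8-fold higher number from compound 1 to compound 3 (0.44 log units; beyond the scatter) in this assay, the only step shown, and it lies beyond the scatter. The change removes the four-membered ring and the nitrogen, yet the hydrogen-bond donor and acceptor counts stay the same. Nothing shown gives a cause for this step. From the compounds shown here alone, whether the ring, the nitrogen or the chain carries the step stays open, since all of them change together. Going by these compounds, how a longer hydroxyalkyl chain or a carboxylic acid on this sulfur would read also stays open.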